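Removing a Side Chain in Two Related Amide Series

The source may report more compounds than this note shows. Statements on the series, on what has been measured and on what is new or still open speak of the compounds shown alone.

Compound 1 `COC(=O)[C@H](CCSC)NC(=O)c1ccc(OC[C@H]2COc3ccccc3O2)cc1-c1ccccc1C`: 6600 nM
Compound 2 `COC(=O)CNC(=O)c1ccc(OC[C@H]2COc3ccccc3O2)cc1-c1ccccc1C`: 27000 nM
Compound 3 `COC(=O)[C@H](CCSC)NC(=O)c1ccc(C(=O)NC[C@H]2COc3ccccc3O2)cc1-c1ccccc1C`: 87000 nM

In a functional assay (HSMC cells, Homo sapiens) for antiproliferative activity, with a stated time of 72 h (on this read-out higher numbers stand for weaker inhibition and lower numbers for stronger inhibition), compound 1 gives 6600 nM and compound 2 gives 27000 nM. The two differ only by hydrogen in place of 2-(methylsulfanyl)ethyl on a saturated chain carbon bound to an amide-type nitrogen and a carbonyl carbon, and this change produced a 4.1-fold higher number from compound 1 to compound 2 (0.61 log units; beyond the scatter). Compound 3 gives 87000 nM in this assay, the highest of the three numbers; the difference between its core and that of compound 1 is not broken down here. Compound 4 `COC(=O)CNC(=O)c1ccc(C(=O)NC[C@H]2COc3ccccc3O2)cc1-c1ccccc1C` is related to compound 3 by the same change, (hydrogen in place of 2-(methylsulfanyl)ethyl on a saturated chain carbon bound to an amide-type nitrogen and a carbonyl carbon). Since the place is identical in both pairs, the expected step for compound 4 is a 3.8-fold higher number from compound 3 to compound 4 (0.58 log units; beyond the scatter), set beside the measured step because of a 4.1-fold higher number from compound 1 to compound 2 (0.61 log units; beyond the scatter). Compound 4 is therefore estimated at 330000 nM, most likely between 120000 nM and 900000 nM in this assay.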

Compound 4, half-maximal inhibitory concentration: 113000 nM
Beside the measured number, compound 4's estimate is 2.9-fold (0.47 log units) above it, outside the stated range (below it).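

In this assay, putting hydrogen in place of 2-(methylsulfanyl)ethyl gives a 1.3-fold higher number from compound 3 to compound 4 (0.11 log units; within the scatter), a much smaller step than on the core of compound 1. The same change therefore does not carry over with the same size from one core to the other: the same change on two cores in this assay, a 4.1-fold higher number (0.61 log units; beyond the scatter) from compound 1 to compound 2 and a 1.3-fold higher number (0.11 log units; within the scatter) from compound 3 to compound 4, 3.1-fold (0.50 log units) apart, beyond the scatter of two such steps. This shows that the size of the step depends on the core in these four compounds, but with one pair per core it does not show which feature of the cores is responsible or what the step would be on a third core.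

Going by these compounds, it remains open whether a longer chain or a simple methyl group in place of 2-(methylsulfanyl)ethyl would give steps that differ on the two cores. The same question stands for a carboxylic acid in place of the methyl ester.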